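A New Acyl Group in a Flat Series

The source may hold more compounds than are shown below. What is called first, only, known or untested is meant among the compounds shown, and "the series" means these compounds.

In a functional assay on NCI-H1975 cells (Homo sapiens) for antiproliferative activity (on this read-out lower numbers stand for stronger inhibition and higher numbers for weaker inhibition), compound 1 (`Cc1c2c(n3c1CCNC[C@@H](C)[C@H](C)Nc1cc-3ccc1C(N)=O)CC(C)(C)CC2=O`) reads 27 nM and compound 2 (`Cc1c2c(n3c1CCN(C)C[C@@H](C)[C@H](C)Nc1cc-3ccc1C(N)=O)CC(C)(C)CC2=O`) reads 27 nM while compound 3 (`COCCC(=O)N1CCc2c(C)c3c(n2-c2ccc(C(N)=O)c(c2)N[C@@H](C)[C@H](C)C1)CC(C)(C)CC3=O`) reads 31 nM and so stands level with both within the scatter. Compound 4 (`Cc1c2c(n3c1CCN(C(=O)C1(N)CC1)C[C@@H](C)[C@H](C)Nc1cc-3ccc1C(N)=O)CC(C)(C)CC2=O`) has 1-aminocyclopropyl in place of 2-methoxyethyl on a carbonyl carbon. Going by the values given here, the steps at the amine nitrogen in a ring all stay within the scatter: no change at the digits printed from compound 1 to compound 2 (within the scatter) and a 1.1-fold higher number from compound 1 to compound 3 (0.06 log units; within the scatter) and also a 1.1-fold higher number from compound 2 to compound 3 (0.06 log units; within the scatter) are the only evidence. None of them tests the 1-aminocyclopropyl group directly. In this assay the estimated step is a 1.1-fold lower number from compound 3 to compound 4 (0.04 log units; within the scatter) with no direction favoured and nothing expected beyond the scatter. The estimate for compound 4 is 28 nM with an expected range of (12 nM to 70 nM).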

Compound 4, half-maximal inhibitory concentration: 72 nM
Compound 4: the middle estimate sits 2.6-fold (0.41 log units) below what was measured; the whole stated range lies below it.
By their numbers in this assay, from the lowest: compounds 1, 2 and 3 (each within the scatter of the next); then compound 4.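

In this assay, going by these compounds alone, the group on the carbonyl carbon proves to matter, with a 2.3-fold higher number from compound 3 to compound 4 (0.37 log units; beyond the scatter) as the first step to pass beyond the scatter. The (1-aminocyclopropyl)carbonyl group also reads weaker than hydrogen or methyl on the amine nitrogen, with a 2.7-fold higher number from compound 1 to compound 4 (0.43 log units; beyond the scatter) and a 2.7-fold higher number from compound 2 to compound 4 (0.43 log units; beyond the scatter) on record, while compound 3 shows that an acyl group as such need not cost activity. Nothing here accounts for this loss.

As far as these compounds go, it remains open whether the amine or the three-membered ring drives the change; a plain cyclopropyl or an aminomethyl on the same carbonyl carbon would separate the two.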